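A Fluorine on the Phenyl Arm of Compound 1

A few compounds are considered here, and "the series" means these few. Any claim that something is new, unique, unknown or untested is made for them only; others in the source may bear on it.

Measured compounds:
compound 1, `Nc1ccccc1NC(=O)c1ccc(CSC(=S)N2CCN(c3ccccc3)CC2)cc1`: 42.3%
compound 2, `CN(C(=S)SCc1ccc(C(=O)Nc2ccccc2N)cc1)c1cccnc1`: 46.1%

Two compounds have numbers in a functional assay on MGC-803 cells (Homo sapiens) for antiproliferative activity, read by CCK-8 assay, with a stated time of 72 h, tested at 2 uM; on this read-out higher numbers stand for a stronger effect at the one concentration tested and lower numbers for a weaker effect. Compound 1 `Nc1ccccc1NC(=O)c1ccc(CSC(=S)N2CCN(c3ccccc3)CC2)cc1` gives 42.3% in this assay, and compound 2 `CN(C(=S)SCc1ccc(C(=O)Nc2ccccc2N)cc1)c1cccnc1` gives 46.1%. Compound 1 holds the lower of the two numbers, but the gap to compound 2 lies within the scatter of repeated measurements, so the two values cannot be told apart.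

Compound 3 `Nc1ccccc1NC(=O)c1ccc(CSC(=S)N2CCN(c3ccccc3F)CC2)cc1` has yet to be measured in this assay. It differs from compound 1 in one place: fluoro in place of hydrogen on an aromatic carbon. The fluoro sits on an aromatic carbon of a six-membered aromatic ring of carbon only, ortho to a large group; cut one bond further out, the change reads phenyl to 2-fluorophenyl.

For the measured compounds named here, no step between measured compounds is available to guide the expectation, since compounds 1 and 2 differ in more than one place. The step expected from compound 1 to compound 3, a number 2.7 percentage points higher from compound 1 to compound 3 (within the scatter), is estimated to be small, with no change beyond the scatter in either direction. Compound 3 is therefore expected to give about 45% in this assay, within a range from 25% to 65%.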

Compound 3, a percentage reported as inhibition, at one concentration (the size of the read-out at that concentration, not a potency): 33.7%
Compound 3: the middle estimate sits 11.3 percentage points above what was measured, within the range that was stated.
By their numbers in this assay, from the lowest: compounds 3, 1 and 2 (each within the scatter of the next, the first and the last beyond it).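

In this assay, fluoro in place of hydrogen on an aromatic carbon of the phenyl arm, ortho to a large group, gives a number 8.6 percentage points lower from compound 1 to compound 3 (within the scatter). For the compounds shown here, this is the first step that changes only one place, and it shows that the change from phenyl to 2-fluorophenyl leaves the read-out at this concentration within what repeated measurements can separate, which compounds 1 and 2, differing in more than one place, could not show. Nothing available here bears on why the step has this size.

The compounds shown leave open whether a larger or different group on the same aromatic carbon, such as chloro, methoxy, trifluoromethyl or an amine, would move the number beyond the scatter. They also leave open whether fluoro on another carbon of that ring would give a step of similar size, and how the change would read across a range of concentrations, since a single concentration gives no potency.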